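Compound 3 and a long side chain

The compounds below may be only part of what the source reports. "The series", "measured", "known", "first", "only" and "open" are said of these compounds alone.

Measured in an ADME assay on a cell-free system (plasma, Mus musculus) for metabolic stability, read by LC-MS, tested at 2 uM; a higher number here means that the compound lasts longer, a lower number that the compound disappears faster:
- Compound 1 `CN1CCC(c2ccc3c(c2)oc(=O)n3C(=O)NCCCCc2ccc(F)cc2)CC1`: 0.333 h
- Compound 2 `CN1CCN(c2ccc3c(c2)oc(=O)n3C(=O)NCCCCc2ccccc2)C(=O)C1`: 0.333 h
- Compound 3 `CC(C)CNC(=O)n1c(=O)oc2cc(C3CCN(C)CC3)ccc21`: 1.33 h

Compound 3 has the highest number of the three, and the gap to each of the others lies beyond the scatter. Compound 4 `CN1CCC(c2ccc3c(c2)oc(=O)n3C(=O)NCCCCc2ccccc2)CC1` has 3-phenylpropyl in place of isopropyl on a saturated chain carbon bound to an amide-type nitrogen. Within the data shown here, the one measured step that bears on this is a 4.0-fold higher number from compound 1 to compound 3 (0.60 log units; beyond the scatter), where isopropyl replaced 3-(4-fluorophenyl)propyl. The new change runs the opposite way, towards a closely related long group. A drop of similar size is therefore expected in this assay, and the expected step is a 4.0-fold lower number from compound 3 to compound 4 (0.61 log units; beyond the scatter). Compound 4 is estimated at 0.33 h, with an expected range of 0.17 h to 0.67 h.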

Compound 4, half-life: 0.833 h
Compound 4: middle estimate off by 2.5-fold (0.40 log units), on the low side; the whole stated range lies below it.
By their numbers in this assay, from the lowest: compounds 1 and 2 (each within the scatter of the next); then compounds 4 and 3 (each within the scatter of the next).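

In this assay the swap to 3-phenylpropyl gives a 1.6-fold lower number from compound 3 to compound 4 (0.20 log units; within the scatter) and so stays within the scatter: at this place, the long chain with its aromatic ring cannot be told apart from isopropyl. Larger steps appear elsewhere on the molecule, where hydrogen in place of fluoro on an aromatic carbon gives a 2.5-fold higher number from compound 1 to compound 4 (0.40 log units; beyond the scatter) and 1-methylpiperidin-4-yl in place of 4-methyl-2-oxopiperazin-1-yl gives a 2.5-fold higher number from compound 2 to compound 4 (0.40 log units; beyond the scatter) with the long chain kept.

Still open, from the compounds shown here alone, is how a chain ending in an amine or a carboxylic acid would read here. Nothing measured explains why these numbers differ.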